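The compounds below may be only part of what the source reports. "The series", "measured", "known", "first", "only" and "open" are said of these compounds alone.

Measured in a physicochemical assay for lipophilicity; on this read-out higher numbers stand for higher lipophilicity and lower numbers for lower lipophilicity:
- Compound 1 `C[C@H]1CC[C@@H]2[C@@H](OC(=O)[C@]23CC(c2ccc(Cl)cc2)=NO3)[C@]2(C)C(=O)C=C[C@@]12O`: 2.09
- Compound 2 `C[C@H]1CC[C@@H]2[C@@H](OC(=O)[C@]23CC(c2ccc(O)cc2)=NO3)[C@]2(C)C(=O)C=C[C@@]12O`: 0.932

Going by the values given here, compound 2, at 0.932, is the lower of the two, and the only comparison is compound 1 at 2.09. Compound 3 `C[C@H]1CC[C@@H]2[C@@H](OC(=O)[C@]23CC(c2ccc([N+](=O)[O-])cc2)=NO3)[C@]2(C)C(=O)C=C[C@@]12O` is not yet measured. Its change is nitro in place of hydroxy on an aromatic carbon, para to a large group. Among the compounds with values here, one measured step bears on this, a number 1.16 log units lower from compound 1 to compound 2 (beyond the scatter), a large one that put hydroxy in place of chloro on the same carbon. Within the data shown here, no nitro compound has been measured, so only part of that step is expected to be reversed, in the upward direction. The expected step is a number 0.52 log units higher from compound 2 to compound 3 (beyond the scatter). Compound 3 is estimated at 1.45, with an expected range of 1.05 to 1.9.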

Compound 3, partition coefficient: 1.37
For compound 3 the middle estimate is 0.08 log units above the measured one; measured number inside the range.
By their numbers in this assay, from the lowest: compound 2; then compound 3; then compound 1.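

In this assay, the change from hydroxy to nitro gives a number 0.44 log units higher from compound 2 to compound 3 (beyond the scatter) and the change from chloro to nitro gives a number 0.72 log units lower from compound 1 to compound 3 (beyond the scatter) on the same aromatic carbon. This one carbon therefore now separates three groups, and compound 3, which has no hydrogen-bond donor in this place, still stands short of compound 1. Going by these compounds, whether an amine or a carboxylic acid here would fall within the span of these three numbers stays open. No measurement offered here accounts for the order of the three groups.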